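The compounds below may be only part of what the source reports. "The series", "measured", "known", "first", "only" and "open" are said of these compounds alone.

Measured in an assay on CHO cells for displacement of a labelled ligand from adenosine receptor A3 (Homo sapiens), with a stated time of 60 min; a lower number here means a stronger inhibitor, a higher number a weaker inhibitor:
compound 1 `CCCCC#Cc1nc(NCc2cccc(Cl)c2)c2ncn([C@H]3[C@H](O)[C@H](O)[C@@H]4C[C@@H]43)c2n1` gives 7.8 nM
compound 2 `CCCCC#Cc1nc(NCc2cccc(I)c2)c2ncn([C@H]3[C@H](O)[C@H](O)[C@@H]4C[C@@H]43)c2n1` gives 12 nM
compound 3 `CCCCC#Cc1nc(NC2CCCC2)c2ncn([C@H]3[C@H](O)[C@H](O)[C@@H]4C[C@@H]43)c2n1` gives 160 nM

Compound 2 stands second highest of the three numbers. Its nearest neighbour is compound 1, with a 1.5-fold higher number from compound 1 to compound 2 (0.19 log units; within the scatter), a step within the scatter; the far end is compound 3, with a 13-fold higher number from compound 2 to compound 3 (1.12 log units; beyond the scatter).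

Compound 4 `CCCCC#Cc1nc(NCc2cccc(F)c2)c2ncn([C@H]3[C@H](O)[C@H](O)[C@@H]4C[C@@H]43)c2n1` has not been measured. The change from compound 2 is fluoro in place of iodo on an aromatic carbon. For the measured compounds named here, the only measured step that bears on a swap of this kind is a 1.5-fold higher number from compound 1 to compound 2 (0.19 log units; within the scatter), which stays within the scatter. The large steps of a 21-fold higher number from compound 1 to compound 3 (1.31 log units; beyond the scatter) and a 13-fold higher number from compound 2 to compound 3 (1.12 log units; beyond the scatter) concern exchange of the whole benzyl group for cyclopentyl and carry no information on the substituent on the ring. Chloro and iodo alone do not establish a pattern, and fluoro is untested in this series, so the range is kept somewhat wide. No step beyond the scatter is expected in this assay, no change at the digits printed from compound 2 to compound 4 (within the scatter). Compound 4 is estimated at 12 nM, within 5 nM to 30 nM.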

Compound 4, inhibition constant: 16 nM
For compound 4 the middle estimate is 1.3-fold (0.12 log units) below the measured one; low and high end bracket the measured number.
By their numbers in this assay, from the lowest: compounds 1, 2 and 4 (each within the scatter of the next, the first and the last beyond it); then compound 3.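

In this assay, fluoro in place of iodo on this aromatic carbon stays within the scatter (a 1.3-fold higher number from compound 2 to compound 4 (0.12 log units; within the scatter)), so a third halogen at this place cannot be separated from iodo. Fluoro in place of chloro gives the first step among the halogens that lies beyond the scatter, though only a modest one (a 2.1-fold higher number from compound 1 to compound 4 (0.31 log units; beyond the scatter)); since compound 2 lies within the scatter of both compound 1 and compound 4, the three halogens fall into no clear order. The advantage of the substituted benzyl group over cyclopentyl also holds with fluoro (a 10-fold lower number from compound 3 to compound 4 (1.00 log units; beyond the scatter)), now across all three halogens.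

From the compounds shown here alone, whether a non-halogen group on this carbon, such as methoxy, nitrile, an amine or a carboxylic acid, would keep the number in this range remains open. No available data explain the differences between these compounds.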